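This account rests on a few compounds, and the source may have more. Where it says the series, first, only, none or still open, it means among the compounds named here.

Compound 1 `c1ccc(CNC2CCN(CCCc3c[nH]c4ccc(-n5cnnc5)cc34)CC2)cc1` — 4.6 nM
Compound 2 `c1ccc(C2CCCCN2C2CCN(CCCc3c[nH]c4ccc(-n5cnnc5)cc34)CC2)cc1` — 1.9 nM
Compound 3 `CN(CC1CCN(CCCc2c[nH]c3ccc(-n4cnnc4)cc23)CC1)C(=O)Nc1ccccc1` — 5.9 nM

Three compounds built on the same core were tested in an assay on CHO cells for displacement of a labelled ligand from 5-hydroxytryptamine receptor 1D (Homo sapiens); a lower number here means a stronger inhibitor, a higher number a weaker inhibitor. Compound 1 gives 4.6 nM, the second highest of the three numbers. Compound 3 gives 5.9 nM, a value that sits within the scatter of compound 1. Compound 2 gives 1.9 nM, a number lower than that of compound 1 by more than the scatter. Within the data shown here, no two of the measured compounds differ in only one place, so no single-change step among them can be read off.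

Compound 4 `c1cncc(CNC2CCN(CCCc3c[nH]c4ccc(-n5cnnc5)cc34)CC2)c1` has not yet been measured in this assay. It differs from compound 1 by pyridin-3-yl in place of phenyl on a saturated chain carbon bound to an amine nitrogen. Among the measured compounds shown here, with no measured step of this kind to lean on, the expectation is a step from compound 1 to compound 4 of a 1.4-fold higher number from compound 1 to compound 4 (0.15 log units; within the scatter), small and not clearly beyond the scatter, if anything toward a slightly higher number. Compound 4 is thus expected to give about 6.5 nM, with a range from 2.2 nM to 19 nM.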

Compound 4, half-maximal inhibitory concentration: 35 nM
Beside the measured number, compound 4's estimate is 5.4-fold (0.73 log units) below it; the whole stated range lies below it.
By their numbers in this assay, from the lowest: compound 2; then compounds 1 and 3 (each within the scatter of the next); then compound 4.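

In this assay, the change from phenyl to pyridin-3-yl on a saturated chain carbon bound to an amine nitrogen gives a 7.6-fold higher number from compound 1 to compound 4 (0.88 log units; beyond the scatter), the only single-change step among the compounds shown. It shows that this position does not accept every six-membered aromatic ring alike: the heavy-atom count stays the same, a ring carbon gives way to nitrogen and one hydrogen-bond acceptor enters, yet the step lies beyond the scatter. Nothing available accounts for the size of this step.

From the compounds shown here alone, what pyridin-2-yl or pyridin-4-yl would give in the same place remains open, so a single step cannot tell whether the ring nitrogen's location matters. Also open, going by these compounds, is whether a fluorophenyl or a thiophene ring would be tolerated there as well as phenyl.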